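This account rests on a few compounds, and the source may have more. Where it says the series, first, only, none or still open, it means among the compounds named here.

Compound 1 `C#Cc1cn([C@@H]2O[C@H](CO)[C@@H](O)[C@H]2O)c2ncnc(NC)c12` is the ethynyl member of the series with methylamino on the core. In a functional assay on A549 cells (Homo sapiens), read by MTT assay, with a stated time of 72 h (on this read-out lower numbers stand for stronger inhibition and higher numbers for weaker inhibition), compound 1 gives > 20000 nM, which is a limit of the assay and not a number (the limit of > 20000 nM in this assay, at which 1 of the 3 values shown sits). Compound 2 `C#Cc1cn([C@@H]2O[C@H](CO)[C@@H](O)[C@H]2O)c2ncnc(OC)c12` carries methoxy in place of methylamino; in this assay compound 2 gives 8160 nM. This change, (methoxy in place of methylamino on an aromatic carbon), made an at least 2.4-fold lower number from compound 1 to compound 2 (0.38 log units; beyond the scatter), the size of the step being open at one end because the limit of > 20000 nM in this assay, at which 1 of the 3 values shown sits, caps what compound 1 shows.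

Compound 3 `CNc1ncnc2c1c(-c1ccco1)cn2[C@@H]1O[C@H](CO)[C@@H](O)[C@H]1O` keeps methylamino but has furan-2-yl in place of ethynyl, the difference between the two cores being (furan-2-yl in place of ethynyl on an aromatic carbon); in this assay compound 3 gives 2570 nM, and the step is an at least 7.7-fold lower number from compound 1 to compound 3 (0.89 log units; beyond the scatter). Between compound 2 and compound 3 no single-point step is counted; their values alone show compound 3 lower.

Compound 4 `COc1ncnc2c1c(-c1ccco1)cn2[C@@H]1O[C@H](CO)[C@@H](O)[C@H]1O` differs from compound 3 by methoxy in place of methylamino on an aromatic carbon, the same change as from compound 1 to compound 2, on a place described in the same words. Beside the earlier step, the step from compound 3 to compound 4 is expected to be a 2.6-fold lower number from compound 3 to compound 4 (0.41 log units; beyond the scatter), resting on an at least 2.4-fold lower number from compound 1 to compound 2 (0.38 log units; beyond the scatter). Compound 4 is estimated at 1000 nM, likely between 300 nM and 3500 nM.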

Compound 4, half-maximal inhibitory concentration: 30 nM
The estimate for compound 4 lay 33-fold (1.52 log units) above the measured number; measured number outside the range, below it.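

In this assay, methoxy in place of methylamino gives a lower number on both cores, and on the core carrying furan-2-yl the step is large, an 86-fold lower number from compound 3 to compound 4 (1.93 log units; beyond the scatter); furan-2-yl in place of ethynyl, with methoxy on the core, likewise gives a 270-fold lower number from compound 2 to compound 4 (2.43 log units; beyond the scatter). The direction of the methoxy change therefore carries across the two cores shown, but two pairs do not establish a rule for the series, and its size cannot be compared: the same change on two cores in this assay, an at least 2.4-fold lower number (0.38 log units; beyond the scatter) from compound 1 to compound 2 and an 86-fold lower number (1.93 log units; beyond the scatter) from compound 3 to compound 4; the limit leaves it open whether they differ The furan-2-yl change has the same direction on both cores, and the same caution applies to its size: the same change on two cores in this assay, an at least 7.7-fold lower number (0.89 log units; beyond the scatter) from compound 1 to compound 3 and a 270-fold lower number (2.43 log units; beyond the scatter) from compound 2 to compound 4; the limit leaves it open whether they differ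

Still open, from the compounds shown here alone, is whether the methoxy step keeps its direction or size with a third group in place of ethynyl or furan-2-yl, such as phenyl or thiophen-2-yl. Also open, going by these compounds, is how a longer chain such as ethoxy, or an amine such as dimethylamino, would compare with methoxy on the core of compound 4.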